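A few compounds are considered here, and "the series" means these few. Any claim that something is new, unique, unknown or untested is made for them only; others in the source may bear on it.

Measured so far in a functional assay on A549 cells (Homo sapiens) for antiproliferative activity, read by CCK-8 assay, with a stated time of 72 h; on this read-out lower numbers stand for stronger inhibition and higher numbers for weaker inhibition:
- compound 1 `O=C(Nc1cccc(-c2oc3cc(-c4ccc(F)cc4)ccc3c(=O)c2O)c1)c1ccccc1F`: 4410 nM
- compound 2 `COc1ccc(C(=O)Nc2cccc(-c3oc4cc(-c5ccc(F)cc5)ccc4c(=O)c3O)c2)cc1`: 8700 nM
- compound 3 `COc1ccccc1C(=O)Nc1cccc(-c2oc3cc(-c4ccc(F)cc4)ccc3c(=O)c2O)c1`: 11700 nM

All three compounds share the same core and differ only in the ring attached to the carbonyl carbon of the amide. Compound 3 gives the highest number of the three; its gap to compound 2 lies within the scatter, while the step of a 2.7-fold higher number from compound 1 to compound 3 (0.42 log units; beyond the scatter) is beyond it, so compound 3 sits at the weaker end of this small set.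

Compound 4 `O=C(Nc1cccc(-c2oc3cc(-c4ccc(F)cc4)ccc3c(=O)c2O)c1)c1ccc(Br)cc1F` is not yet measured. It differs from compound 3 in one place: 4-bromo-2-fluorophenyl in place of 2-methoxyphenyl on a carbonyl carbon. Of the measured steps, the one that bears on this change most directly is a 2.7-fold higher number from compound 1 to compound 3 (0.42 log units; beyond the scatter), where methoxy in place of fluoro made the number larger; going back the other way, from a methoxy-bearing ring to a fluoro-bearing one, should therefore make it smaller. Nothing measured speaks to the bromine that enters at the same time, so that part of the change is uncertain.

On that basis a modest step downward, a 2.3-fold lower number from compound 3 to compound 4 (0.37 log units; beyond the scatter), is expected, and compound 4 is estimated at 5000 nM, within a range of 2000 nM to 12000 nM.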

Compound 4, half-maximal inhibitory concentration: 46100 nM
Compound 4: the middle estimate sits 9.2-fold (0.96 log units) below what was measured, and the stated range ends below it.
By their numbers in this assay, from the lowest: compounds 1, 2 and 3 (each within the scatter of the next, the first and the last beyond it); then compound 4.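

The clearest reading comes from placing bromo on a hydrogen-bearing aromatic carbon of the ring on the amide carbonyl: in this assay this single change gives a 10-fold higher number from compound 1 to compound 4 (1.02 log units; beyond the scatter) and counts as a large loss of activity. For the compounds shown here, the earlier compounds showed only smaller shifts when the ring changed, such as a 2.7-fold higher number from compound 1 to compound 3 (0.42 log units; beyond the scatter) and so this is the first sign that this part of the molecule can strongly affect the read-out. The 4-bromo-2-fluorophenyl ring also falls behind both methoxy-bearing rings, with a 3.9-fold higher number from compound 3 to compound 4 (0.60 log units; beyond the scatter) and a 5.3-fold higher number from compound 2 to compound 4 (0.72 log units; beyond the scatter) and this makes compound 4 the weakest of the four, although nothing available accounts for the loss.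

From the compounds shown here alone, it remains open whether the loss is particular to bromo or would also follow from a chloro, methyl or dimethylamino group in its place. A 4-bromophenyl ring, carrying no fluoro, would show whether the bromo has the same effect on its own.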